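The source may report more compounds than this note shows. Statements on the series, on what has been measured and on what is new or still open speak of the compounds shown alone.

Measured so far, in a functional assay on KB cells (Homo sapiens) for antiproliferative activity, read by sulforhodamine B assay, with a stated time of 3 days; a lower number here means that less compound is needed, a higher number that more compound is needed for the effect:
- compound 1 `CCC1=C(O)c2c(oc(-c3ccc(O)cc3)cc2=O)C(CC)(CC)C1=O` gives 20.6 uM
- compound 2 `CCC1=C(O)c2c(oc(-c3cccc(C(F)(F)F)c3)cc2=O)C(CC)(CC)C1=O` gives 35.7 uM

Compound 1 has the lower of these two numbers, though the two values lie within the usual scatter of each other, so nothing separates them. Compound 3 `CCC1=C(O)c2c(oc(-c3ccccc3F)cc2=O)C(CC)(CC)C1=O` differs from compound 1 in one place: 2-fluorophenyl in place of 4-hydroxyphenyl on an aromatic carbon. Among the compounds with values here, with no measured step of this kind to lean on, a change from compound 1 to compound 3 of no more than the scatter is expected in this assay, if anything towards a slightly higher number. Compound 3 is therefore estimated at 30 uM (range 10 uM to 90 uM), an expected step of a 1.5-fold higher number from compound 1 to compound 3 (0.16 log units; within the scatter).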

Compound 3, concentration for half-maximal effect: > 56.2 uM
Compound 3 ended at the assay's limit (the forecaster's own chance of this, stated with the estimate: 5%); at least 1.8-fold (0.27 log units) between middle value and limit.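

In this assay compound 3 gives > 56.2 uM, which is a limit of the assay and not a number. Putting 2-fluorophenyl in place of 4-hydroxyphenyl on this aromatic carbon gives an at least 2.7-fold higher number from compound 1 to compound 3 (0.43 log units; beyond the scatter), the only single-place step shown, so this carbon's substituent can matter in this assay. The printed size is only a lower bound on the step: the limit of > 56.2 uM in this assay, at which 1 of the 3 values shown sits.

The step swaps a hydroxyl for a fluorine and moves the substituent around the phenyl ring at once, so these two changes cannot be told apart. From the compounds shown here alone, how 4-fluorophenyl, 2-hydroxyphenyl or 4-aminophenyl would read at this carbon remains open.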